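The source may report more compounds than this note shows. Statements on the series, on what has been measured and on what is new or still open speak of the compounds shown alone.

Measured in an in vitro ADME assay on microsomes from liver (Homo sapiens) for metabolic stability; a lower number here means that the compound disappears faster, a higher number that the compound lasts longer:
Compound 1 `CC(C)(C)[C@H]1C(O)=C(C2=NS(=O)(=O)c3c(OCc4ncon4)cccc32)C(=O)N1Cc1ccc(F)c(Cl)c1`: > 1 h, a limit of the assay and not a number.
Compound 2 `CC(C)(C)CCN1C(=O)C(C2=NS(=O)(=O)c3c(OCC(N)=O)cccc32)=C(O)[C@@H]1C(C)(C)C`: 0.8 h.

Going by the values given here, compound 2 holds the only true number so far. The other reading is a limit, so the half-life of compound 2 cannot be ranked against it.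

Compound 3 `CC(C)(C)CCN1C(=O)C(C2=NS(=O)(=O)c3c(OCc4ncon4)cccc32)=C(O)[C@@H]1C(C)(C)C` has not yet been measured. It differs from compound 2 in one place: 1,2,4-oxadiazol-3-yl in place of carbamoyl on a saturated chain carbon bound to an oxygen on an aromatic ring. In words, 1,2,4-oxadiazol-3-yl stands in place of carbamoyl on a saturated chain carbon bound to an oxygen on an aromatic ring.

Among the compounds with values here, no measured pair shows what this exchange does in this assay, so the expectation is a cautious one, with no clear direction. The step of a 1.1-fold lower number from compound 2 to compound 3 (0.06 log units; within the scatter) is expected to stay within the usual scatter of repeated measurements. The estimated half-life of compound 3 is 0.7 h, with an expected range from 0.35 h to 1.2 h.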

Compound 3, half-life: 0.733 h
Compound 3: middle estimate off by 1.0-fold (0.02 log units), on the low side; measured number inside the range.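

In this assay, 1,2,4-oxadiazol-3-yl in place of carbamoyl on this saturated chain carbon bound to an oxygen on an aromatic ring gives a 1.1-fold lower number from compound 2 to compound 3 (0.04 log units; within the scatter), so the half-lives of the two compounds cannot be told apart even though the one hydrogen-bond donor of carbamoyl is gone. The reading for compound 1 is a limit of the assay and not a number: the limit of > 1 h in this assay, at which 1 of the 3 values shown sits. Neopentyl in place of 3-chloro-4-fluorophenyl on a saturated chain carbon bound to an amide-type nitrogen in a ring gives an at least 1.3-fold lower number from compound 1 to compound 3 (0.13 log units; that floor lies within the scatter), so this exchange shows no difference beyond the scatter, though the true gap may be larger.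

On these data alone, whether an amine or a carboxylic acid on the same chain carbon would give a similar half-life stays open. Also open, as far as these compounds go, is whether carbamoyl and 1,2,4-oxadiazol-3-yl would still match alongside 3-chloro-4-fluorophenyl.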